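Triazolylmethyl amides: a para-substituent swap on the benzyl group

The source may report more compounds than this note shows. Statements on the series, on what has been measured and on what is new or still open speak of the compounds shown alone.

Measured so far:
compound 1, `CC(C)n1ncc2c(C(=O)NCc3cn(-c4cccc(F)c4)nn3)cccc21`: 36100 nM
compound 2, `CC(C)n1ncc2c(C(=O)NCc3cn(Cc4ccc(C#N)cc4)nn3)cccc21`: 18200 nM

Both compounds were tested in a functional assay on PC-3 cells (Homo sapiens) for inhibition, read by MTT assay, with a stated time of 72 h; on this read-out lower numbers stand for stronger inhibition and higher numbers for weaker inhibition. Compound 1 gives 36100 nM and compound 2 gives 18200 nM. Within the data shown here, the only step between them, a 2.0-fold lower number from compound 1 to compound 2 (0.30 log units; within the scatter), exchanges the whole group on the aromatic nitrogen of the triazole and stays within the scatter, so the two numbers cannot be put in order; compound 2 simply has the lower of the two numbers, with compound 1 as its only neighbour.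

Compound 3, `COc1ccc(Cn2cc(CNC(=O)c3cccc4c3cnn4C(C)C)nn2)cc1`, is not yet measured. It differs from compound 2 by methoxy in place of cyano on an aromatic carbon, that is, at the position para to the large group on the benzyl ring. Among the measured compounds shown here, no measured step touches this position: the one step available, from compound 1 to compound 2, changes a different part of the molecule and was itself within the scatter. There is therefore nothing in the data to support a shift in either direction for compound 3, and the expectation is a step of a 1.1-fold higher number from compound 2 to compound 3 (0.04 log units; within the scatter), not beyond the scatter. Compound 3 is accordingly estimated at 20000 nM in this assay, with a range from 7000 nM to 60000 nM.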

Compound 3, half-maximal inhibitory concentration: 34000 nM
The estimate for compound 3 lay 1.7-fold (0.23 log units) below the measured number, and the stated range covers the measured number.
By their numbers in this assay, from the lowest: compounds 2, 3 and 1 (each within the scatter of the next).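

In this assay, among these compounds, the exchange of methoxy for cyano on an aromatic carbon, para to a large group, gives a 1.9-fold higher number from compound 2 to compound 3 (0.27 log units; within the scatter), the first measured step at this position. It stays within the scatter, so the data do not separate these two groups here, although they differ in what enters and leaves: a nitrile with its triple bond goes, and an oxygen-linked methyl comes in. The second new step, which exchanges the whole group on the aromatic nitrogen, gives a 1.1-fold lower number from compound 1 to compound 3 (0.03 log units; within the scatter) and also stays within the scatter, as does the earlier exchange on that nitrogen, so none of the three compounds can be ranked against another. Nothing measured here bears on these results beyond the cell read-out itself.

The compounds shown leave open whether a different group at this position, such as an amine, a carboxylic acid or a longer alkoxy chain, would produce a step beyond the scatter. They also leave open whether any change to the shared core or the amide, both the same in all three compounds, would move the number further than these exchanges did.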